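The source may hold more compounds than are shown below. What is called first, only, known or untested is meant among the compounds shown, and "the series" means these compounds.

Measured compounds:
compound 1 `COc1cc(C)cc(-c2c(-c3ccnc(-c4ccc(N(C)C)cc4)c3)cnn2CC#N)c1` — -6%
compound 2 `Cc1cc(O)cc(-c2nn(CC#N)cc2-c2ccnc(-c3ccc(N(C)C)cc3)c2)c1` — -37%

In a functional assay on IGROV-1 cells (Homo sapiens) for cytotoxicity, read by sulforhodamine B assay, with a stated time of 48 h, tested at 10 uM (a higher number here means a weaker effect of the compound at the concentration tested, a lower number a stronger effect), compound 1 gives -6%, the highest of the two numbers; compound 2 gives -37%, a number that lies beyond the scatter below it. Compound 3 `COc1cc(C)cc(-c2c(-c3ccnc(-c4ccc(C(C)=O)cc4)c3)cnn2CC#N)c1` has not yet been measured in this assay. It differs from compound 1 in one place: acetyl in place of dimethylamino on an aromatic carbon. No step between measured compounds of this kind exists, so the account expects a step of a number 4 percentage points lower from compound 1 to compound 3 (within the scatter) that does not go beyond the scatter, because compound 1 gives -6% and little activity is shown there. Compound 3 is estimated at -10%, within -40% to 15%.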

Compound 3, a percentage reported as activity, at one concentration (the size of the read-out at that concentration, not a potency): 14%
Compound 3: the middle estimate sits 24 percentage points below what was measured; the measured number falls inside the stated range.
By their numbers in this assay, from the lowest: compound 2; then compound 1; then compound 3.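

In this assay, acetyl in place of dimethylamino on this aromatic carbon, para to a large group, gives a number a number 20 percentage points higher from compound 1 to compound 3 (beyond the scatter) and thus a weaker effect at the concentration tested. This position therefore responds to the change, even though both groups have the same count of heavy atoms and hydrogen-bond acceptors. Nothing available explains this step.

As far as these compounds go, whether a carboxylic acid or a primary amine at this position would read closer to acetyl or to dimethylamino remains open. So does whether a longer chain, such as propionyl, would behave like acetyl.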